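Compound 3 to compound 4: thiophen-2-yl for furan-3-yl

The source may hold more compounds than are shown below. What is called first, only, known or untested is meant among the compounds shown, and "the series" means these compounds.

Measured in a functional assay on HepG2 cells (Homo sapiens) for antiproliferative activity, read by XTT assay, with a stated time of 72 h; a higher number here means a weaker inhibitor, a lower number a stronger inhibitor:
- compound 1 `CSc1ncnc2c1c(-c1cccs1)cn2[C@@H]1O[C@H](CO)[C@@H](O)[C@H]1O`: > 20000 nM (a limit)
- compound 2 `CNc1ncnc2c1c(-c1cccs1)cn2[C@@H]1O[C@H](CO)[C@@H](O)[C@H]1O`: > 20000 nM (a limit)
- compound 3 `Cc1ncnc2c1c(-c1ccoc1)cn2[C@@H]1O[C@H](CO)[C@@H](O)[C@H]1O`: 5320 nM

Among the compounds with values here, compound 3 gives the only actual number here, 5320 nM. The other two values are limits. Compound 4 `Cc1ncnc2c1c(-c1cccs1)cn2[C@@H]1O[C@H](CO)[C@@H](O)[C@H]1O` carries thiophen-2-yl in place of furan-3-yl on an aromatic carbon. Within the data shown here, no measured step covers this change. The one available, a step that the two limits leave unreadable from compound 1 to compound 2, has no readable size and concerns a different group. Compound 1 and compound 2 both carry thiophen-2-yl and both sit at the limit of > 20000 nM in this assay, at which 2 of the 3 values shown sit, though each differs from compound 4 elsewhere on the core. In this assay, a modest move toward weaker inhibition, close to the scatter, is therefore expected, with the estimated step of a 1.7-fold higher number from compound 3 to compound 4 (0.23 log units; within the scatter). The expected value for compound 4 is 9000 nM, within an estimated range of 1500 nM to 25000 nM.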

Compound 4, half-maximal inhibitory concentration: > 15000 nM
Compound 4 was reported as a limit; the forecaster's own chance of this, stated with the estimate: 35%; middle value at least 1.6-fold (0.22 log units) from the limit.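

In this assay, within the data shown here, thiophen-2-yl in place of furan-3-yl on an aromatic carbon gives an at least 2.8-fold higher number from compound 3 to compound 4 (0.45 log units; beyond the scatter), the first readable step. With the methyl group unchanged, this exchange is the only difference between the two compounds, so the read-out depends on which five-membered aromatic ring sits here. Compound 4 is reported as a limit: the limit of > 15000 nM in this assay, at which 1 of the 4 values shown sits.

The steps from compound 1 and compound 2 to compound 4 cannot be read. Still open, as far as these compounds go, are how furan-3-yl reads with methylamino or methylsulfanyl on the core, and how phenyl or thiophen-3-yl reads at this position.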